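This account rests on a few compounds, and the source may have more. Where it says the series, first, only, none or still open, it means among the compounds named here.

Three compounds built on one shared core have so far been run in a functional assay on the whole organism with Rattus norvegicus as the target, with a stated time of 3 h, at a dose of 20 mg/kg by the oral route; on this read-out lower numbers stand for less inhibition and higher numbers for more inhibition at the one dose given (going by the name of the read-out). Compound 1, `CNC(=O)/C=C1\CCc2c(C)cc(F)cc21`, gives 40% in this assay. Compound 2, `CNC(=O)/C=C1\CCc2c(Cl)cc(Cl)cc21`, gives 34%. Compound 3, `NC(=O)/C=C1\CCc2c(F)cc(Cl)cc21`, gives 36%. The gaps between these three numbers all fall inside the usual scatter of repeated measurements, so compound 1 cannot be set apart from compound 2 or compound 3 on the numbers shown; the three read as much the same.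

Compound 4, `Cc1cc(F)cc2c1CC/C2=C\C(N)=O`, is the next compound to be measured. It differs from compound 1 in a single place: hydrogen in place of methyl on an amide-type nitrogen. Compound 3 already carries the carbamoyl group that compound 4 will carry, while compound 1 and compound 2 carry the methylcarbamoyl group. The values give no sign that this part of the molecule moves the read-out: compound 3, with 36%, sits within the scatter of compound 1 and compound 2. Within the data shown here, no step between two measured compounds that differ only in this place is available, so the expectation rests on that comparison alone. Compound 4 is therefore expected to give 37%, with a likely range from 22% to 52%. The expected step of a number 3 percentage points lower from compound 1 to compound 4 (within the scatter) is estimated to be none beyond the scatter.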

Compound 4, a percentage reported as inhibition, in the whole organism at one dose (the size of the read-out at that dose, not a potency): 24%
Beside the measured number, compound 4's estimate is 13 percentage points above it; measured number inside the range.
By their numbers in this assay, from the lowest: compounds 4, 2, 3 and 1 (each within the scatter of the next, the first and the last beyond it).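

In this assay, putting hydrogen in place of methyl on the amide-type nitrogen gives a number 16 percentage points lower from compound 1 to compound 4 (beyond the scatter). This is the only pair shown that differs in this one place, so it isolates a change that the earlier compounds could not separate from other differences between them, and it shows that, with the rest of compound 1 held fixed, the methyl on this nitrogen does make a difference to the read-out, though a modest one. No measurement shown explains why the number falls with this change.

Among these compounds, the single pair also leaves open whether the step carries over to the other substituent patterns on the shared core, such as those of compound 2 and compound 3, each of which has no partner differing only at this nitrogen. From the compounds shown here alone, it is equally open what an ethyl group, a longer chain or a second methyl on the same nitrogen would do, and whether the number would rise further, hold steady or fall with any of them.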